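Cyclopropyl to 4-Methylphenyl: an Expected Flat Step

This account rests on a few compounds, and the source may have more. Where it says the series, first, only, none or still open, it means among the compounds named here.

Measured so far:
compound 1 `Cc1cc(N2CC[C@@H](C)[C@@H](N(C)c3ncnc4[nH]ccc34)C2)n2nc(SCC3CC3)nc2n1`: 36500 nM
compound 2 `Cc1cc(N2CC[C@@H](C)[C@@H](N(C)c3ncnc4[nH]ccc34)C2)n2nc(SCc3ccc(Br)cc3)nc2n1`: 28000 nM

In a functional assay on BGC-823 cells (Homo sapiens) for inhibition, read by MTT assay, with a stated time of 72 h (a lower number here means a stronger inhibitor, a higher number a weaker inhibitor), compound 1 gives the highest of the two numbers, with compound 2 nearest to it. Among the compounds with values here, the only measured step, a 1.3-fold lower number from compound 1 to compound 2 (0.12 log units; within the scatter), is within the scatter. Compound 3 `Cc1ccc(CSc2nc3nc(C)cc(N4CC[C@@H](C)[C@@H](N(C)c5ncnc6[nH]ccc56)C4)n3n2)cc1` differs from compound 1 by 4-methylphenyl in place of cyclopropyl on a saturated chain carbon bound to a sulfur. The step to compound 2 bears on it, since both put a six-membered aromatic ring of carbon only in place of cyclopropyl. Compound 3 is therefore expected to give 28000 nM, ranging from 12000 nM to 65000 nM. The expected step of a 1.3-fold lower number from compound 1 to compound 3 (0.12 log units; within the scatter) should stay within the scatter because a 1.3-fold lower number from compound 1 to compound 2 (0.12 log units; within the scatter) did.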

Compound 3, half-maximal inhibitory concentration: 69500 nM
Compound 3: middle estimate off by 2.5-fold (0.39 log units), on the low side; measured number outside the range, above it.
By their numbers in this assay, from the lowest: compounds 2, 1 and 3 (each within the scatter of the next, the first and the last beyond it).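

In this assay, the group on the saturated chain carbon bound to a sulfur now shows that the substituent on the aromatic ring matters: methyl in place of bromo on an aromatic carbon gives a 2.5-fold higher number from compound 2 to compound 3 (0.39 log units; beyond the scatter), a modest step. Against cyclopropyl, 4-methylphenyl gives a 1.9-fold higher number from compound 1 to compound 3 (0.28 log units; within the scatter), so neither aromatic group leaves the scatter around compound 1. No evidence at hand accounts for the step from bromo to methyl. On these data alone, what an amine or a carboxylic acid would give on that aromatic carbon remains open.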